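Cyclohexyl in Place of Dimethylfuran on the Alkyne

The source may report more compounds than this note shows. Statements on the series, on what has been measured and on what is new or still open speak of the compounds shown alone.

Measured so far:
Compound 1 `CNC(=O)[C@@]12C[C@@H]1[C@@H](n1cnc3c(NC)nc(C#Cc4cccc(C(F)(F)F)c4)nc31)[C@H](O)[C@@H]2O`: 10%
Compound 2 `CNC(=O)[C@@]12C[C@@H]1[C@@H](n1cnc3c(NC)nc(C#Cc4cc(C)c(C)o4)nc31)[C@H](O)[C@@H]2O`: 15%

Both compounds were tested in an assay on CHO cells for displacement of a labelled ligand from adenosine receptor A1 (Homo sapiens), read by scintillation counting, with a stated time of 60 min, tested at 10 uM; a lower number here means less inhibition, a higher number more inhibition at the concentration tested (going by the name of the read-out). Within the data shown here, compound 2 carries the larger of the two numbers, with compound 1 as its only neighbour, but the step of a number 5 percentage points higher from compound 1 to compound 2 (within the scatter) lies within the scatter, so the two compounds cannot be told apart on these data.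

Compound 3 `CNC(=O)[C@@]12C[C@@H]1[C@@H](n1cnc3c(NC)nc(C#CC4CCCCC4)nc31)[C@H](O)[C@@H]2O` is the next point. Its change from compound 2 is cyclohexyl in place of 4,5-dimethylfuran-2-yl on a triple-bonded carbon. Among the measured compounds shown here, the only measured step, from compound 1 to compound 2, also exchanged the group on the triple-bonded carbon and gave a number 5 percentage points higher from compound 1 to compound 2 (within the scatter); no measured step replaces an aromatic ring there with a non-aromatic one. With nothing pointing either way, compound 3 is expected to move by no change at the digits printed from compound 2 to compound 3 (within the scatter), no more than the scatter. The estimated inhibition of compound 3 is 15%, within a range of 0% to 35%.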

Compound 3, a percentage reported as inhibition, at one concentration (the size of the read-out at that concentration, not a potency): 15%
Beside the measured number, compound 3's estimate shows no gap at the digits printed; measured number inside the range.
By their numbers in this assay, from the lowest: compounds 1, 2 and 3 (each within the scatter of the next).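

In this assay, the group on the triple-bonded carbon can now be a non-aromatic ring with no step beyond the scatter: cyclohexyl replaces 4,5-dimethylfuran-2-yl (no change at the digits printed from compound 2 to compound 3 (within the scatter)) and 3-(trifluoromethyl)phenyl (a number 5 percentage points higher from compound 1 to compound 3 (within the scatter)). The earlier compounds carried only aromatic rings at this position, so these steps are the first to show that, among the listed compounds, the read-out stays within the scatter without one, and also without the furan's hydrogen-bond acceptor. Nothing available explains why these groups cannot be told apart.

From the compounds shown here alone, whether an amine or a carboxylic acid at the end of a longer chain on the triple-bonded carbon would stand apart from these three compounds remains open. Also open, going by these compounds, is whether their potencies differ, which a reading at a single concentration cannot settle.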